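This account rests on a few compounds, and the source may have more. Where it says the series, first, only, none or still open, it means among the compounds named here.

Measured so far:
- compound 1 `C=CC(=O)N1CC(NC(=O)Cn2cc(C(=O)N(C)Cc3ccccc3)c3cc(Br)ccc32)C1`: 1.67 h
- compound 2 `C=CC(=O)N1CC(NC(=O)Cn2c(C)c(C(=O)N3CCc4c(cccc4OC)C3)c3cc(Cl)cc(C)c32)C1`: 1.67 h
- compound 3 `C=CC(=O)N1CC(NC(=O)Cn2ccc3cc(Br)ccc32)C1`: 1.67 h

All three values come from a physicochemical assay for pharmacokinetics, read by LC-MS, in phosphate buffer, at pH 7.4, in the presence of a further agent that is not named here; a higher number here means that the compound lasts longer, a lower number that the compound disappears faster. Compound 1 stands level with compound 2 and compound 3 at the digits shown; none of the three is separated from the others by more than the usual scatter of this assay. Going by the values given here, the one single-point step among them, no change at the digits printed from compound 1 to compound 3 (within the scatter), shows that removing the whole amide side group from the aromatic carbon leaves the half-life unchanged, which suggests that this part of the molecule does little to the read-out.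

The new compound, compound 4 `C=CC(=O)N1CC(NC(=O)Cn2cc(C(=O)N3CCc4cc(F)ccc4C3)c3cc(Br)ccc32)C1`, is compound 1 with a different amine on the amide carbonyl: 6-fluoro-1,2,3,4-tetrahydroisoquinolin-2-yl in place of benzyl(methyl)amino on a carbonyl carbon. Compound 2, which carries a related cyclic amine on its amide, shows the same half-life as compound 1, and the step to compound 3 was flat. The step I expect, no change at the digits printed from compound 1 to compound 4 (within the scatter), is therefore none beyond the scatter. Compound 4 is expected to give about 1.67 h, with a range from 0.9 h to 3.2 h.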

Compound 4, half-life: 1.67 h
Estimate against measurement, compound 4: no gap at the digits printed; low and high end bracket the measured number.
By their numbers in this assay, from the lowest: compounds 1, 2, 3 and 4 (each within the scatter of the next).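

In this assay, the swap of benzyl(methyl)amino for 6-fluoro-1,2,3,4-tetrahydroisoquinolin-2-yl on a carbonyl carbon gives no change at the digits printed from compound 1 to compound 4 (within the scatter), so this amine can be exchanged for a larger, ring-bearing one that also carries a fluorine without any visible effect on the half-life. The earlier single-place step removed the whole amide group, whereas this one keeps the carbonyl and alters only the amine attached to it, a narrower test that also comes out flat. Nothing measured here explains this flat result.

As far as these compounds go, whether the half-life would stay level with a piperazine or a morpholine on this carbonyl remains open. All the compounds shown also carry the same acryloyl group, so the effect of replacing it, for example with a propanoyl group, remains open too.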